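Aryl swap on the shared core: fluorine position moved

This account rests on a few compounds, and the source may have more. Where it says the series, first, only, none or still open, it means among the compounds named here.

Compound 1 `O=S(=O)(c1ccc(F)c(Cl)c1)c1cnc2cc(F)ccc2c1-c1cccc(F)c1`: 0.25 mL/min
Compound 2 `N#Cc1cccc(S(=O)(=O)c2cnc3cc(F)ccc3c2-c2cccc(F)c2)c1`: 0.78 mL/min
Compound 3 `O=S(=O)(c1ccc(F)c(F)c1)c1cnc2cc(F)ccc2c1-c1cccc(F)c1`: 0.6 mL/min

In an ADME assay on microsomes from liver (Homo sapiens) for metabolic stability, tested at 2.5 uM (a higher number here means faster removal of the compound, a lower number slower removal), compound 1 gives the lowest number of the three measured. Compound 3 lies nearest, a 2.4-fold higher number from compound 1 to compound 3 (0.38 log units; beyond the scatter), and compound 2 lies furthest, a 3.1-fold higher number from compound 1 to compound 2 (0.49 log units; beyond the scatter). Between the other two the step is a 1.3-fold lower number from compound 2 to compound 3 (0.11 log units; within the scatter). All three measured steps change the group on the sulfonyl sulfur and leave the 3-fluorophenyl on the shared core untouched.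

Compound 4 `O=S(=O)(c1ccc(F)c(Cl)c1)c1cnc2cc(F)ccc2c1-c1ccc(F)cc1` differs from compound 1 elsewhere: 4-fluorophenyl in place of 3-fluorophenyl on an aromatic carbon. Going by the values given here, no measured step bears on this change, so the expectation rests on compound 1 alone. Among the compounds with values here, with the same atoms joined differently and no measured precedent pointing either way, no step beyond the scatter is expected in this assay, and the estimate sits close to compound 1 with a range wide enough to allow either direction. The estimated value for compound 4 is 0.3 mL/min, within 0.12 mL/min to 0.75 mL/min. This corresponds to an expected step of a 1.2-fold higher number from compound 1 to compound 4 (0.08 log units; within the scatter).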

Compound 4, intrinsic clearance in a liver preparation (reported as CLH), per the amount of preparation that the assay uses: 0.69 mL/min
Estimate against measurement, compound 4: 2.3-fold (0.36 log units) below; measured number inside the range.
By their numbers in this assay, from the lowest: compound 1; then compounds 3, 4 and 2 (each within the scatter of the next).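

Moving the fluorine on the aryl group of the shared core registers in this assay, with 4-fluorophenyl in place of 3-fluorophenyl giving a 2.8-fold higher number from compound 1 to compound 4 (0.44 log units; beyond the scatter). Going by these compounds alone, this is the first measured change at this position, on the aromatic carbon opposite the ring nitrogen, and it shows that the number responds here as well as to the group on the sulfonyl sulfur, even though the atoms stay the same. Nothing at hand bears on why this step arises.

4-fluorophenyl is shown only with 3-chloro-4-fluorophenyl on the sulfonyl sulfur, so whether the step carries over to the 3-cyanophenyl or 3,4-difluorophenyl partners remains open. On these data alone, how an unsubstituted phenyl or a methoxyphenyl at this position would read in this assay also remains open.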